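The compounds below may be only part of what the source reports. "The series", "measured", "known", "first", "only" and "open" are said of these compounds alone.

Compound 1 `COc1ccc(NC(=O)c2cccc(/C=C3\CC(=O)N(c4ccccc4)C3=O)c2)cc1` carries an amide whose nitrogen bears a 4-methoxyphenyl group, attached to the shared core. In an ADME assay on HCT-116 cells (Homo sapiens) for cytotoxicity, read by MTT assay, with a stated time of 72 h (a higher number here means a weaker inhibitor, a lower number a stronger inhibitor), compound 1 reaches only a limit of the measurement, > 100000 nM. Compound 2 `O=C(Nc1cccc(F)c1)c1cccc(/C=C2\CC(=O)N(c3ccccc3)C2=O)c1` differs from compound 1 in a single place: 3-fluorophenyl in place of 4-methoxyphenyl on an amide-type nitrogen. In this assay compound 2 likewise stops at a limit, > 100000 nM. The size of a step that the two limits leave unreadable from compound 1 to compound 2 therefore cannot be read. Compound 3 `CCCCCN1C(=O)C/C(=C\c2cccc(C(=O)Nc3ccc(OC)cc3)c2)C1=O` keeps the amide of compound 1 and changes the ring-bound nitrogen instead: pentyl in place of phenyl on an amide-type nitrogen in a ring. In this assay compound 3 again gives only a limit, > 100000 nM. The size of a step that the two limits leave unreadable from compound 1 to compound 3 is equally unreadable. Behind all three outcomes stands one fact: the limit of > 100000 nM in this assay, at which 3 of the 3 values shown sit.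

Compound 4 `CCCCCN1C(=O)C/C(=C\c2cccc(C(=O)Nc3cccc(F)c3)c2)C1=O` has not yet been measured. It stands to compound 3 as compound 2 stands to compound 1, the difference being (3-fluorophenyl in place of 4-methoxyphenyl on an amide-type nitrogen); this is the same change, made at the same place, while the two cores differ by pentyl in place of phenyl on an amide-type nitrogen in a ring. Because compound 1 and compound 2 both sit at the limit of > 100000 nM in this assay, at which 3 of the 3 values shown sit, the change gave no readable movement there. The step of a number no higher from compound 3 to compound 4 (the limit leaves the size open) is expected to be small. Compound 4 is accordingly expected to give about 100000 nM in this assay, with a likely range from 50000 nM to 300000 nM, most probably reported again as a limit. That expectation rests on the limit of compound 3, > 100000 nM.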

Compound 4, half-maximal inhibitory concentration: > 100000 nM
Compound 4: a limit, no number; the forecaster's own chance of this, stated with the estimate: 85%; the middle value sits exactly at the limit.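

In this assay compound 4 gives only a limit, > 100000 nM. Neither the step from compound 3 to compound 4 nor the step from compound 2 to compound 4 can therefore be read, and one fact lies behind both: the limit of > 100000 nM in this assay, at which 4 of the 4 values shown sit.

The compounds shown leave open whether either change alters cytotoxicity at all: none of them gives an actual number to compare.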